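Dropping the Fluorine from a Benzothiazole Amide

This account rests on a few compounds, and the source may have more. Where it says the series, first, only, none or still open, it means among the compounds named here.

Measured so far, in a functional assay on A549 cells (Homo sapiens) for cytotoxicity, read by MTT assay, with a stated time of 48 h; on this read-out higher numbers stand for weaker inhibition and lower numbers for stronger inhibition:
Compound 1, `COc1ccc(-c2cc(C(=O)Nc3nc4ccc(Cl)cc4s3)nc3cc(-c4ccccc4)nn23)cc1`, gives 3090 nM.
Compound 2, `COc1ccc(-c2cc(C(=O)Nc3nc4ccc(F)cc4s3)nc3cc(-c4ccccc4)nn23)cc1`, gives 11700 nM.
Compound 3, `COc1cc(-c2cc(C(=O)Nc3nc4ccc(F)cc4s3)nc3cc(-c4ccccc4)nn23)cc(OC)c1OC`, gives 22400 nM.

Compound 2 stands second highest of the three numbers. Its neighbour is compound 3, which lies within the scatter of it; compound 1 is further off, and that gap is beyond the scatter, as the step of a 3.8-fold higher number from compound 1 to compound 2 (0.58 log units; beyond the scatter) shows.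

The compound not yet measured is compound 4, `COc1ccc(-c2cc(C(=O)Nc3nc4ccccc4s3)nc3cc(-c4ccccc4)nn23)cc1`. It differs from compound 2 in one place: hydrogen in place of fluoro on an aromatic carbon.

Among the compounds with values here, only one measured step touches this position. It is a 3.8-fold higher number from compound 1 to compound 2 (0.58 log units; beyond the scatter), where one halogen replaced another, and the number rose. The step of a 1.9-fold higher number from compound 2 to compound 3 (0.28 log units; within the scatter) concerns a different part of the molecule and says nothing about the benzothiazole ring. Within the data shown here, no step shows what happens when the halogen is taken away altogether, so the direction is uncertain; the expectation is for little change or a mild rise, within or near the scatter.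

Compound 4 is therefore expected to give about 15000 nM in this assay, somewhere between 5000 nM and 45000 nM, which means an estimated step of a 1.3-fold higher number from compound 2 to compound 4 (0.11 log units; within the scatter).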

Compound 4, half-maximal inhibitory concentration: 1540 nM
The estimate for compound 4 lay 9.7-fold (0.99 log units) above the measured number; the measured number lies below the stated range.
By their numbers in this assay, from the lowest: compounds 4 and 1 (each within the scatter of the next); then compounds 2 and 3 (each within the scatter of the next).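

In this assay, within the data shown here, the first step to show what happens when the halogen is removed altogether is a 7.6-fold lower number from compound 2 to compound 4 (0.88 log units; beyond the scatter), so the fluoro on the 6-fluoro-1,3-benzothiazol-2-yl group is not a neutral passenger. The second comparison, a 2.0-fold lower number from compound 1 to compound 4 (0.30 log units; within the scatter), shows that hydrogen and chloro cannot be told apart here. That leaves compound 2, with its fluoro, on the high side of both neighbours with a gap beyond the scatter in each case, so the earlier chloro-to-fluoro step no longer reads as a sign that halogens in general set the number at this position. Nothing given here explains why fluoro stands apart from hydrogen and chloro on this ring.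

Three substituents at one position cannot show whether a bromine atom, a methyl group or an amine there would group with hydrogen and chloro or with fluoro. From the compounds shown here alone, it also remains open whether swapping fluoro for hydrogen would bring a similar drop in compound 3, which carries 3,4,5-trimethoxyphenyl in place of 4-methoxyphenyl.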